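Swapping a Sulfur-Bearing Ring for a Difluoropropyl Chain

The source may report more compounds than this note shows. Statements on the series, on what has been measured and on what is new or still open speak of the compounds shown alone.

Of the compounds shown here, three sharing one core have been tested in a functional assay on isolated protein for inhibition of Glucose-dependent insulinotropic receptor (Homo sapiens), read by HTRF and cAMP accumulation; on this read-out lower numbers stand for an effect already at smaller amounts and higher numbers for an effect only at larger amounts of compound. Compound 1 `Cc1nc(S(C)(=O)=O)ccc1Oc1ncnc(OC2CCN(C(=O)O[C@H](C)C(F)(F)F)CC2)c1F` gives 9.2 nM. Compound 2 `Cc1nc(S(C)(=O)=O)ccc1Oc1ncnc(OC2CCN(C(=O)OC3COC3)CC2)c1F` gives 326 nM, and compound 3 `Cc1nc(S(C)(=O)=O)ccc1Oc1ncnc(OC2CCN(C(=O)SC3CC3)CC2)c1F` gives 24.9 nM. Among these three numbers compound 3 holds the second highest place: the step from the best compound was a 2.7-fold higher number from compound 1 to compound 3 (0.43 log units; beyond the scatter), while the step from the weakest was a 13-fold lower number from compound 2 to compound 3 (1.12 log units; beyond the scatter).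

The untested compound 4 `CCC(F)(F)C(=O)N1CCC(Oc2ncnc(Oc3ccc(S(C)(=O)=O)nc3C)c2F)CC1` differs from compound 3 in one place: a group of 5 heavy atoms (3 carbon, 2 fluorine; no ring) in place of a group of 4 heavy atoms (3 carbon, 1 sulfur; one three-membered non-aromatic ring of carbon only), on a carbonyl carbon. Within the data shown here, two measured steps touch the same spot on the carbonyl carbon. The step of a 2.7-fold higher number from compound 1 to compound 3 (0.43 log units; beyond the scatter) shows that putting the sulfur-bearing three-membered ring in place of a fluorinated chain raised the number modestly, whereas a 13-fold lower number from compound 2 to compound 3 (1.12 log units; beyond the scatter) shows that the same ring lowered the number strongly when it replaced the oxetan-3-yl ring. Among the measured compounds shown here, compound 4 carries a fluorinated chain with no ring, which makes it closer in kind to compound 1 than to compound 2, although its entering group contains no sulfur and no oxygen, and no measured pair tests exactly that. A modest lowering is therefore expected, a 1.7-fold lower number from compound 3 to compound 4 (0.22 log units; within the scatter), with wide uncertainty. Compound 4 is expected to give 15 nM, within a range from 4 nM to 60 nM.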

Compound 4, half-maximal effective concentration: 17.4 nM
Estimate against measurement, compound 4: 1.2-fold (0.06 log units) below; the range from low to high includes it.
By their numbers in this assay, from the lowest: compounds 1, 4 and 3 (each within the scatter of the next, the first and the last beyond it); then compound 2.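

In this assay, among these compounds, the new result shows that the atom joined to the carbonyl carbon need not be oxygen or sulfur, as it was in all the earlier compounds: with 1,1-difluoropropyl, carbon takes that role, and both a 1.4-fold lower number from compound 3 to compound 4 (0.16 log units; within the scatter) and a 1.9-fold higher number from compound 1 to compound 4 (0.28 log units; within the scatter) stay within the usual scatter. The same group differs sharply from the oxetane-bearing group, with a 19-fold lower number from compound 2 to compound 4 (1.27 log units; beyond the scatter), so a large loss at this position is not tied to removing the oxygen or sulfur link, and among the four compounds it appears only with (oxetan-3-yl)oxy. No measurement available here explains why these groups give the numbers they do.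

The compounds shown leave open whether the two fluorine atoms matter, which a plain propyl group on the same carbonyl carbon would test directly. They also leave open how far this position accepts other kinds of group, such as a longer chain like 1,1-difluorobutyl or an amine on the carbonyl carbon.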